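Replacing the 2,5-dimethoxyphenyl group of compound 1

The source may report more compounds than this note shows. Statements on the series, on what has been measured and on what is new or still open speak of the compounds shown alone.

Among the measured compounds shown here, in an ADME assay on KB cells (Homo sapiens) for cytotoxicity, read by MTT assay, with a stated time of 72 h (a lower number here means a stronger inhibitor, a higher number a weaker inhibitor), compound 1 `COc1ccc(OC)c(C2=C(c3cc(OC)c(OC)c(OC)c3)C(=O)CC2O[SiH2]C(C)(C)C)c1` gives 10 ug/mL, the only actual number so far. Compound 2 `COc1ccc(OC)c(C2=C(c3cc(OC)c(OC)c(OC)c3)C(=O)CC2O)c1` reads > 100 ug/mL, which is a limit of the assay. For the measured compounds named here, the one measured step, an at least 10-fold higher number from compound 1 to compound 2 (1.00 log units; beyond the scatter), lies beyond the scatter and took place on an oxygen on a saturated carbon.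

Compound 3 `COc1ccc(C2=C(c3cc(OC)c(OC)c(OC)c3)C(=O)CC2O[SiH2]C(C)(C)C)cc1O` keeps the group lost in that step and differs elsewhere: 3-hydroxy-4-methoxyphenyl in place of 2,5-dimethoxyphenyl on a double-bonded ring carbon, with 3-hydroxy-4-methoxyphenyl in place of 2,5-dimethoxyphenyl on a double-bonded ring carbon. Going by the values given here, no measured step touches this group, and the step to compound 2 gives no direct guide to its size. Compound 1, at 10 ug/mL, remains the only reference point. A modest move towards a lower number is expected, a 3.3-fold lower number from compound 1 to compound 3 (0.52 log units; beyond the scatter), with wide uncertainty. For compound 3 the estimated value in this assay is 3 ug/mL, with an expected range from 0.2 ug/mL to 30 ug/mL.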

Compound 3, half-maximal inhibitory concentration: 6.5 ug/mL
Estimate against measurement, compound 3: 2.2-fold (0.34 log units) below, within the range that was stated.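

The step of a 1.5-fold lower number from compound 1 to compound 3 (0.19 log units; within the scatter) shows that, in this assay, this exchange on the double-bonded ring carbon leaves the read-out within the scatter, so 3-hydroxy-4-methoxyphenyl and 2,5-dimethoxyphenyl cannot be told apart here. The earlier step concerned only the oxygen on a saturated carbon, whereas this one shows that the aryl group can be exchanged for one carrying 1 hydrogen-bond donor, in place of 0 hydrogen-bond donors, without a change beyond the scatter. Unlike compound 2, compound 3 gives an actual number rather than a limit, so this comparison can be read: the limit of > 100 ug/mL in this assay, at which 1 of the 3 values shown sits.

From the compounds shown here alone, it remains open whether an amine or a carboxylic acid in place of the hydroxy group of compound 3 would give a similar number. Also open, going by these compounds, is how the 3-hydroxy-4-methoxyphenyl group would read with the free hydroxy group of compound 2 in place of the silyl ether.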